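Chloro to nitro exchange on a shared core

The source may report more compounds than this note shows. Statements on the series, on what has been measured and on what is new or still open speak of the compounds shown alone.

Compound 1 `O=C(CCc1nnc(-c2ccc(Cl)cc2)o1)c1ccccc1`, compound 2 `O=C(CCc1nnc(-c2ccc([N+](=O)[O-])cc2)o1)c1ccccc1` and compound 3 `Cc1ccc(C(=O)CCc2nnc(-c3ccc(Cl)cc3)o2)c(C)c1` have been measured; compound 4 `Cc1ccc(C(=O)CCc2nnc(-c3ccc([N+](=O)[O-])cc3)o2)c(C)c1` has not. In a functional assay on the whole organism (strain Wistar) for inhibition, with Rattus norvegicus as the target, with stated times of 30 min and 2 h, at a dose of 20 mg/kg by the oral route (on this read-out higher numbers stand for more inhibition at the one dose given (going by the name of the read-out) and lower numbers for less inhibition), compound 1 gives 42%, compound 2 gives 40.9% and compound 3 gives 53.3%. The change nitro in place of chloro on an aromatic carbon produced a number 1.1 percentage points lower from compound 1 to compound 2 (within the scatter). The cores of compound 1 and compound 3 differ by 2,4-dimethylphenyl in place of phenyl on a carbonyl carbon, which produced a number 11.3 percentage points higher from compound 1 to compound 3 (beyond the scatter). Compound 4 arises from compound 3 by nitro in place of chloro on an aromatic carbon, the same change as seen between compound 1 and compound 2, with the same surroundings at the place where it is made. For compound 4 the step is expected to be a number 1.3 percentage points lower from compound 3 to compound 4 (within the scatter), because the earlier instance of this change gave a number 1.1 percentage points lower from compound 1 to compound 2 (within the scatter). Compound 4 is therefore estimated at 52%, with the likely range between 40% and 63%.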

Compound 4, a percentage reported as inhibition, in the whole organism at one dose (the size of the read-out at that dose, not a potency): 40%
For compound 4 the middle estimate is 12 percentage points above the measured one; measured number inside the range.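

In this assay, nitro in place of chloro on the core of compound 3 gives a number 13.3 percentage points lower from compound 3 to compound 4 (beyond the scatter), yet this step does not separate from the earlier instance: the same change on two cores in this assay, a number 1.1 percentage points lower (within the scatter) from compound 1 to compound 2 and a number 13.3 percentage points lower (beyond the scatter) from compound 3 to compound 4, 12.2 percentage points apart, within the scatter of two such steps. Likewise, 2,4-dimethylphenyl in place of phenyl on the nitro-bearing core gives a number 0.9 percentage points lower from compound 2 to compound 4 (within the scatter), and this step does not separate from its earlier instance either: the same change on two cores in this assay, a number 11.3 percentage points higher (beyond the scatter) from compound 1 to compound 3 and a number 0.9 percentage points lower (within the scatter) from compound 2 to compound 4, 12.2 percentage points apart, within the scatter of two such steps. Going by these compounds alone, with only two instances of each change, the data show neither that a step carries over unchanged from one core to another nor that its size depends on the core.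

The compounds shown leave open how an amine or a methoxy group in place of chloro would read out. They also leave open the effect of a longer chain on the shared core.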